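Replacing acetyl with cyano when every value is a limit

The source may report more compounds than this note shows. Statements on the series, on what has been measured and on what is new or still open speak of the compounds shown alone.

Compound 1 `Cc1cn(/C=C/C#N)c(=O)[nH]c1=O`: in a functional assay on HeLa cells (Homo sapiens) for inhibition (on this read-out higher numbers stand for weaker inhibition and lower numbers for stronger inhibition), compound 1 gives > 100000 nM, which is a limit of the assay and not a number.
Compound 2 `CC(=O)/C=C/n1cc(C)c(=O)[nH]c1=O`: in this assay compound 2 gives > 100000 nM, again a limit.
Compound 3 `CC(=O)/C=C/n1c(=O)ccn([C@H]2C[C@H](O)[C@@H](CO)O2)c1=O`: in this assay compound 3 gives > 100000 nM, also a limit.

The change from compound 2 to compound 1 is cyano in place of acetyl on a double-bonded chain carbon bound to a double-bonded chain carbon. Its size is a step that the two limits leave unreadable from compound 2 to compound 1, since the limit of > 100000 nM in this assay, at which 3 of the 3 values shown sit, places both ends at the same limit.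

Compound 4 `N#C/C=C/n1c(=O)ccn([C@H]2C[C@H](O)[C@@H](CO)O2)c1=O` has not yet been measured. It differs from compound 3 by cyano in place of acetyl on a double-bonded chain carbon bound to a double-bonded chain carbon, the same change as from compound 2 to compound 1, made on a different core; the difference between the two cores is not broken down here.

For compound 4 the step from compound 3 is expected to be a step that the limit leaves unreadable from compound 3 to compound 4, which rests on the limit of > 100000 nM in this assay, at which 3 of the 3 values shown sit, showing the same change leaving compound 2 and compound 1 both at the limit. The estimate for compound 4 in this assay is therefore 200000 nM, between 100000 nM and 1000000 nM, and most likely only a limit again.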

Compound 4, half-maximal inhibitory concentration: > 100000 nM
Compound 4 was reported as a limit; the forecaster's own chance of this, stated with the estimate: 90%; the middle value lies beyond the limit too.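

Compound 3 and compound 4 both sit at a limit and not at a number, so no step can be read between them for cyano in place of acetyl: the limit of > 100000 nM in this assay, at which 4 of the 4 values shown sit. The compounds shown leave open how strongly any of them inhibits in this assay, and whether this swap changes that at all.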